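This account rests on a few compounds, and the source may have more. Where it says the series, first, only, none or still open, it means among the compounds named here.

The numbers come from an assay for inhibition of squalene synthase (Rattus norvegicus), using microsomes; on this read-out higher numbers stand for weaker inhibition and lower numbers for stronger inhibition. Compound 1 `CCCCOc1ccc(OCCCNC(C)C)cc1` gives 56 nM. Compound 2 `C=CCc1ccccc1OCCCNC(C)C` gives 56 nM, level with compound 1 at the digits shown, and together these two stand at the highest numbers of the three. Compound 3 `CCC(=O)Nc1ccc(OCCCNC(C)C)c(Cc2ccccc2)c1` gives 0.6 nM, a far lower number than compound 2, and that gap lies beyond the scatter.

Compound 4 `C=CCc1cc(NC(C)=O)ccc1OCCCNC(C)C` has not yet been measured. It differs from compound 2 in one place: acetamido in place of hydrogen on an aromatic carbon. Going by the values given here, no pair of measured compounds isolates this change, so its size can only be judged from what is at hand. In this assay compound 3 gives 0.6 nM while compound 2 gives 56 nM, and that contrast is the nearest pointer, even though compound 3 differs from compound 2 in more than one respect. The step is therefore expected to be a 9.3-fold lower number from compound 2 to compound 4 (0.97 log units; beyond the scatter), toward a lower number and beyond the scatter. Compound 4 is expected to give about 6 nM, within a range from 1.5 nM to 30 nM.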

Compound 4, half-maximal inhibitory concentration: 65 nM
Estimate against measurement, compound 4: 11-fold (1.03 log units) below, and the stated range ends below it.
By their numbers in this assay, from the lowest: compound 3; then compounds 1, 2 and 4 (each within the scatter of the next).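

In this assay, the direct swap of hydrogen for acetamido on this aromatic carbon, meta to the allyl group and para to the group of 8 heavy atoms, gives a 1.2-fold higher number from compound 2 to compound 4 (0.06 log units; within the scatter) and so leaves the two compounds level. Going by these compounds alone, this is the first reading that isolates the change, and it shows that on this core, with the allyl group present, acetamido at this position makes no difference that can be told from the scatter of the read-out. Nothing available here explains why the two numbers stand level.

On these data alone, whether a different group at this position, such as an amine, a carboxylic acid or a longer acyl chain, would also leave the number level remains open. So does whether acetamido would behave the same way with a propyl or benzyl group in place of the allyl group.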